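This account rests on a few compounds, and the source may have more. Where it says the series, first, only, none or still open, it means among the compounds named here.

Measured in a functional assay on Jurkat cells (Homo sapiens) for inhibition, read by CCK-8 assay, with a stated time of 48 h; on this read-out higher numbers stand for weaker inhibition of growth and lower numbers for stronger inhibition of growth:
- Compound 1 `Cc1ccccc1Nc1nc(Nc2ccc(N3CCN(C)CC3)cn2)ncc1Cl`: 8080 nM
- Compound 2 `Cc1ccccc1Nc1nc(Nc2ccc(N3CCCCC3)cn2)ncc1Cl`: > 100000 nM (a limit)
- Compound 3 `CN1CCN(c2ccc(Nc3ncc(Cl)c(NCc4ccc(F)cc4)n3)nc2)CC1`: > 100000 nM (a limit)

Compound 3 has no exact number, since its > 100000 nM is a limit of this assay. It shares this position with compound 2, as the limit of > 100000 nM in this assay, at which 2 of the 3 values shown sit, shows. Only compound 1 gives an exact value.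

Compound 4 `CN1CCN(c2ccc(Nc3ncc(Cl)c(NCc4ccco4)n3)nc2)CC1` is compound 3 with one change: furan-2-yl in place of 4-fluorophenyl on a saturated chain carbon bound to a nitrogen on an aromatic ring. In words, it carries furan-2-yl in place of 4-fluorophenyl on a saturated chain carbon bound to a nitrogen on an aromatic ring. Among the compounds with values here, no measured step exchanges this group directly. The closest is the large at least 12-fold higher number from compound 1 to compound 3 (1.09 log units; beyond the scatter), which introduced the 4-fluorobenzyl group on that nitrogen. The equally large an at least 12-fold higher number from compound 1 to compound 2 (1.09 log units; beyond the scatter) concerns a different group, so it bears little on this change.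

With compound 3 known only as a limit, neither the size nor the direction of the step is firmly set, though a modest move toward stronger inhibition is possible. The expected change is an at least 1.4-fold lower number from compound 3 to compound 4 (0.15 log units; that floor lies within the scatter). Compound 4 is estimated at 70000 nM, with an expected range from 15000 nM to 150000 nM.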

Compound 4, concentration for 50% growth inhibition: > 100000 nM
Compound 4 gave a limit, no number; the forecaster's own chance of this, stated with the estimate: 60%; at least 1.4-fold (0.15 log units) between middle value and limit.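

In this assay, replacing 4-fluorophenyl with furan-2-yl on a saturated chain carbon bound to a nitrogen on an aromatic ring gives no exact value, so the step from compound 3 to compound 4 cannot be read. With 2-methylphenyl replaced by (furan-2-yl)methyl on that nitrogen, the result is an at least 12-fold higher number from compound 1 to compound 4 (1.09 log units; beyond the scatter), so among the compounds shown this large step is not confined to the 4-fluorobenzyl group. Compound 1 remains the only compound with an exact value: the limit of > 100000 nM in this assay, at which 3 of the 4 values shown sit.

As far as these compounds go, how compound 3 and compound 4 compare beyond the limit remains open. It is also unknown whether a phenyl or cyclohexyl group on that nitrogen would give an exact value in this assay.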